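The source may hold more compounds than are shown below. What is called first, only, known or untested is meant among the compounds shown, and "the series" means these compounds.

Measured so far: compound 1 `O=C(C1COc2ccccc2O1)N1N=C(c2ccc(Br)cc2)CC1c1cccc(F)c1` gives 7810 nM; compound 2 `O=C(C1COc2ccccc2O1)N1N=C(c2ccc(Br)cc2)CC1c1ccc(F)cc1` gives 5630 nM; compound 3 `O=C(c1ccc2c(c1)OCCO2)N1N=C(c2ccc(Br)cc2)CC1c1cccc(F)c1` gives 810 nM.

These numbers come from a functional assay on WM 266-4 cells (Homo sapiens) for inhibition, read by MTT assay, with a stated time of 24 h; a higher number here means a weaker inhibitor of growth, a lower number a stronger inhibitor of growth. The three compounds share a core; the unmeasured compound 4 `O=C(c1ccc2c(c1)OCCO2)N1N=C(c2ccc(Br)cc2)CC1c1ccc(F)cc1` shares it too.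

Two kinds of change appear among the measured compounds. The first is 4-fluorophenyl in place of 3-fluorophenyl on a saturated ring carbon; it gave a 1.4-fold lower number from compound 1 to compound 2 (0.14 log units; within the scatter), so compound 1 and compound 2 cannot be told apart by this assay. Among the measured compounds shown here, the second is 2,3-dihydro-1,4-benzodioxin-6-yl in place of 2,3-dihydro-1,4-benzodioxin-2-yl on a carbonyl carbon; it gave a 9.6-fold lower number from compound 1 to compound 3 (0.98 log units; beyond the scatter), which makes compound 3 the one with the lowest number of the three, and its distance from compound 2 is also beyond the scatter.

Compound 4 is reached from compound 3 by 4-fluorophenyl in place of 3-fluorophenyl on a saturated ring carbon. For the measured compounds named here, this is the same change as the one from compound 1 to compound 2: what leaves, what enters and the place around it are described in the same words. Going by the values given here, the only measured example of it, a 1.4-fold lower number from compound 1 to compound 2 (0.14 log units; within the scatter), stayed within the scatter, and one example is a thin basis. The expectation for compound 4 is therefore that it stays close to compound 3, with a step of about a 1.3-fold lower number from compound 3 to compound 4 (0.12 log units; within the scatter), resting on compound 3 at 810 nM together with that earlier step.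

In this assay compound 4 is estimated at 620 nM, expected to fall between 250 nM and 1600 nM.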

Compound 4, concentration for 50% growth inhibition: 3260 nM
Compound 4: middle estimate off by 5.3-fold (0.72 log units), on the low side, and the stated range ends below it.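

In this assay, putting 4-fluorophenyl in place of 3-fluorophenyl on the core with the 2,3-dihydro-1,4-benzodioxin-6-yl group gave a 4.0-fold higher number from compound 3 to compound 4 (0.60 log units; beyond the scatter), so a swap that could not be read on one core made a clear difference on the other: the same change on two cores in this assay, a 1.4-fold lower number (0.14 log units; within the scatter) from compound 1 to compound 2 and a 4.0-fold higher number (0.60 log units; beyond the scatter) from compound 3 to compound 4, 5.6-fold (0.75 log units) apart, beyond the scatter of two such steps

The second change shows the same dependence from the other side, since 2,3-dihydro-1,4-benzodioxin-6-yl in place of 2,3-dihydro-1,4-benzodioxin-2-yl gave a 1.7-fold lower number from compound 2 to compound 4 (0.24 log units; within the scatter) on the cores with 4-fluorophenyl, far less than it gave with 3-fluorophenyl: the same change on two cores in this assay, a 9.6-fold lower number (0.98 log units; beyond the scatter) from compound 1 to compound 3 and a 1.7-fold lower number (0.24 log units; within the scatter) from compound 2 to compound 4, 5.6-fold (0.75 log units) apart, beyond the scatter of two such steps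

Within this series, then, the step seen for either change on one core cannot simply be carried to another, and the gain from the 2,3-dihydro-1,4-benzodioxin-6-yl group appears here only alongside 3-fluorophenyl, but four compounds cannot show why the two places depend on each other or how general this dependence is.

On these data alone, it remains open whether a plain phenyl or a methoxyphenyl on the saturated ring carbon would follow the pattern of 3-fluorophenyl or of 4-fluorophenyl. As far as these compounds go, it is also open whether the same dependence would hold if a chlorine took the place of the bromine on the 4-bromophenyl group.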